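A few compounds are considered here, and "the series" means these few. Any claim that something is new, unique, unknown or untested is made for them only; others in the source may bear on it.

Within the data shown here, in a functional assay on NCI-H460 cells (Homo sapiens) for cytotoxicity, read by MTT assay, with a stated time of 72 h (on this read-out lower numbers stand for stronger inhibition and higher numbers for weaker inhibition), compound 1 `O=c1[nH]/c(=C\c2cccc(Oc3ccc(F)cc3)c2)c(=O)[nH]/c1=C\c1ccccc1` gives 389 nM, the higher of the two numbers measured so far, while compound 2 `COCc1ccc(/C=c2\[nH]c(=O)/c(=C/c3cccc(C(=O)c4ccc(F)cc4)c3)[nH]c2=O)o1` gives 2.9 nM. Compound 3 `O=c1[nH]/c(=C\c2cc3ccccc3o2)c(=O)[nH]/c1=C\c1cccc(Oc2ccc(F)cc2)c1` differs from compound 1 in one place: 1-benzofuran-2-yl in place of phenyl on a double-bonded chain carbon bound to an aromatic carbon. Among the measured compounds shown here, no directly comparable step has been measured, but compound 2 also carries a five-membered aromatic ring with one hetero atom on a double-bonded chain carbon and differs from compound 1 in other places as well, so compound 3 is expected to shift toward stronger inhibition by a 2.6-fold lower number from compound 1 to compound 3 (0.41 log units; beyond the scatter), a moderate step beyond the scatter. Compound 3 is estimated at 150 nM, within 40 nM to 600 nM.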

Compound 3, half-maximal inhibitory concentration: 347 nM
Beside the measured number, compound 3's estimate is 2.3-fold (0.36 log units) below it; low and high end bracket the measured number.
By their numbers in this assay, from the lowest: compound 2; then compounds 3 and 1 (each within the scatter of the next).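

In this assay, replacing phenyl with 1-benzofuran-2-yl on a double-bonded chain carbon bound to an aromatic carbon gives a 1.1-fold lower number from compound 1 to compound 3 (0.05 log units; within the scatter). At this position, then, adding a five-membered aromatic ring with one hetero atom and a hydrogen-bond acceptor to the phenyl-sized ring leaves the number within the scatter. No supporting data account for this result.

Going by these compounds, whether an amine or a carboxylic acid at this position would move the number beyond the scatter remains open. So does whether a simple furan-2-yl ring would behave like 1-benzofuran-2-yl.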